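Aminothiophene ketones: chlorophenyl entering beside the ring sulfur

The source may report more compounds than this note shows. Statements on the series, on what has been measured and on what is new or still open speak of the compounds shown alone.

Measured compounds:
- compound 1, `CC(C)(C)Cc1csc(N)c1C(=O)c1ccc(Cl)cc1`, 5%
- compound 2, `Cc1c(-c2ccccc2)sc(N)c1C(=O)c1ccc(Cl)cc1`, 1%
- compound 3, `CC(C)(C)Cc1csc(N)c1C(=O)c1cccc(Cl)c1`, 8%

In an assay on CHO cells for displacement of a labelled ligand from adenosine receptor A3 (Homo sapiens), read by scintillation counting, tested at 10 uM (a higher number here means more inhibition at the concentration tested (going by the name of the read-out), a lower number less inhibition), compound 1 gives 5%. Its two neighbours lie close on either side: compound 3 with 8% and compound 2 with 1%, both within the usual scatter of compound 1, so the three numbers cannot be put in order.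

Compound 4, `CC(C)(C)Cc1c(-c2ccc(Cl)cc2)sc(N)c1C(=O)c1ccc(Cl)cc1`, carries 4-chlorophenyl in place of hydrogen on an aromatic carbon. Among the measured compounds shown here, no pair of measured compounds shows this change alone. Compound 2, which bears a phenyl on the same ring carbon, gives 1%, a low number like the rest. For the step of no change at the digits printed from compound 1 to compound 4 (within the scatter) no change beyond the scatter is expected. Compound 4 is therefore estimated at 5%, within -5% to 18%.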

Compound 4, a percentage reported as inhibition, at one concentration (the size of the read-out at that concentration, not a potency): 1%
Estimate against measurement, compound 4: 4 percentage points above; the measured number falls inside the stated range.
By their numbers in this assay, from the lowest: compounds 2, 4, 1 and 3 (each within the scatter of the next).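

In this assay, among the compounds shown here, the 4-chlorophenyl on the aromatic carbon next to the ring sulfur, with the neopentyl group kept, gives a number 4 percentage points lower from compound 1 to compound 4 (within the scatter) and so provides the first single-place step. At this position, a group of this size leaves the reading indistinguishable from that of the hydrogen compound, and the number remains low. No supporting data bear on this result.

On these data alone, whether an amine or a carboxylic acid on this same carbon would move the number beyond the scatter remains open.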